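A few compounds are considered here, and "the series" means these few. Any claim that something is new, unique, unknown or untested is made for them only; others in the source may bear on it.

Three amides on a shared core have been measured in a functional assay on Jurkat cells (Homo sapiens) for cytotoxicity, read by luminescence and CellTiter-Glo, with a stated time of 3 days; a higher number here means a weaker inhibitor, a lower number a stronger inhibitor. Compound 1 `O=C(Nc1ccc(C(F)(F)F)cc1)c1ccc(Cl)cc1O` gives 670 nM. Compound 2 `O=C(Nc1ccc(OC(F)(F)F)cc1)c1cc(F)ccc1O` gives 810 nM, and compound 3 `O=C(Nc1ccc(OC(F)(F)F)c(Cl)c1)c1cc(F)ccc1O` gives 700 nM. Among the measured compounds shown here, the only single-point step among them, chloro in place of hydrogen on an aromatic carbon, is a 1.2-fold lower number from compound 2 to compound 3 (0.06 log units; within the scatter), and the number for compound 1 also lies within the scatter of that of compound 2, so the three cannot be told apart in this assay. Compound 4 `O=C(Nc1ccc([N+](=O)[O-])cc1)c1cc(F)ccc1O` differs from compound 2 by nitro in place of trifluoromethoxy on an aromatic carbon. For the measured compounds named here, no measured step introduces a nitro group or removes a trifluoromethoxy group, so nothing measured bears directly on this change. The expectation for compound 4 is therefore a 1.0-fold lower number from compound 2 to compound 4 (0.01 log units; within the scatter), with an estimated value of 800 nM, between 300 nM and 2200 nM.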

Compound 4, half-maximal inhibitory concentration: 940 nM
Compound 4: middle estimate off by 1.2-fold (0.07 log units), on the low side; the measured number falls inside the stated range.
By their numbers in this assay, from the lowest: compounds 1, 3, 2 and 4 (each within the scatter of the next).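

In this assay, nitro in place of trifluoromethoxy on an aromatic carbon, para to a large group, gives a 1.2-fold higher number from compound 2 to compound 4 (0.06 log units; within the scatter). Among the compounds shown here, this is the first measured step at this position, and it shows that a group with fewer heavy atoms, no fluorine and a double bond outside aromatic rings leaves the number within the scatter. No measurement bears on why the number stays there.

From the compounds shown here alone, it remains open whether an amine, a carboxylic acid or a longer chain at this position would give a number beyond the scatter. The compounds shown therefore do not establish whether any group at this position can shift the number.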